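The compounds below may be only part of what the source reports. "The series", "measured", "known", "first", "only" and "open" are said of these compounds alone.

Measured so far in an ADME assay on HEK293 cells (Homo sapiens) for cytotoxicity, read by resazurin assay, with a stated time of 48 h; on this read-out lower numbers stand for higher toxicity in this test and higher numbers for lower toxicity in this test:
- compound 1 `O=S(=O)(Nc1ccc2oc(-c3ccccc3)nc2c1)c1ccc(Cl)c(Cl)c1`: 71000 nM
- compound 3 `O=[N+]([O-])c1cc(S(=O)(=O)Nc2ccc3oc(-c4ccccc4)nc3c2)ccc1Cl`: 90000 nM
- compound 2 `COc1ccccc1S(=O)(=O)Nc1ccc(-c2nc3ccccc3o2)cc1` sits at the assay's limit, > 100000 nM

Compound 1 has the lowest of the two plain numbers; its nearest neighbour is compound 3, with a 1.3-fold higher number from compound 1 to compound 3 (0.10 log units; within the scatter). Compound 4 `O=S(=O)(Nc1ccc2oc(-c3ccccc3)nc2c1)c1ccc(Cl)s1` is not yet measured. It differs from compound 1 only by 5-chlorothiophen-2-yl in place of 3,4-dichlorophenyl on a sulfonyl sulfur. Within the data shown here, the one measured step, nitro in place of chloro on an aromatic carbon, changes a different part of the molecule and stayed within the scatter, so it gives no direct guide to swapping the whole ring on the sulfonyl sulfur. With no step beyond the scatter anywhere, no change beyond the scatter is expected, as a 1.0-fold lower number from compound 1 to compound 4 (0.01 log units; within the scatter). Compound 4 is therefore estimated at 70000 nM, between 25000 nM and 200000 nM.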

Compound 4, half-maximal cytotoxic concentration: > 100000 nM
Compound 4 ended at the assay's limit (the forecaster's own chance of this, stated with the estimate: 30%); middle value at least 1.4-fold (0.15 log units) from the limit.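

In this assay, replacing the whole ring on the sulfonyl sulfur gives an at least 1.4-fold higher number from compound 1 to compound 4 (0.14 log units; that floor lies within the scatter). So a five-membered aromatic ring with one hetero atom can stand there without a lower number, though the true size of the step stays unknown. The value of compound 4 is only a limit, and the read-out offers little room at this end: the limit of > 100000 nM in this assay, at which 2 of the 4 values shown sit.

Still open, from the compounds shown here alone, is whether an amine or a carboxylic acid on this ring would bring the number down. Also open, going by these compounds, is how a longer chain in place of the ring would behave.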